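Swapping a Hexyl Chain for a Phenethyl Group

This account rests on a few compounds, and the source may have more. Where it says the series, first, only, none or still open, it means among the compounds named here.

Of the compounds shown here, three built on one shared core have been tested. Compound 1 `CC(C)COc1ccc2c(Cl)ccnc2c1` carries a short branched chain on the oxygen, and in a functional assay on SK-OV-3 cells (Homo sapiens) for cytotoxicity, read by MTT assay, with a stated time of 48 h (a higher number here means a weaker inhibitor, a lower number a stronger inhibitor), compound 1 gives 3190 nM. Compound 3 `Clc1ccnc2cc(OCc3ccccc3)ccc12` carries a benzyl group on that oxygen, and in this assay compound 3 gives 5170 nM. Compound 2 `CCCCCCOc1ccc2c(Cl)ccnc2c1` carries a hexyl chain on the oxygen. For compound 2 this assay reports only a limit, > 10000 nM, not a number. Compound 2 therefore stands at the limit of > 10000 nM in this assay, at which 1 of the 3 values shown sits.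

Lengthening the chain gave an at least 3.1-fold higher number from compound 1 to compound 2 (0.49 log units; beyond the scatter). Putting a ring where the chain was gave an at least 1.9-fold lower number from compound 2 to compound 3 (0.28 log units; that floor lies within the scatter), while a 1.6-fold higher number from compound 1 to compound 3 (0.21 log units; within the scatter). Compound 4 `Clc1ccnc2cc(OCCc3ccccc3)ccc12` differs from compound 2 by phenyl in place of butyl on a saturated chain carbon, two bonds along the chain from an oxygen on an aromatic ring. For the measured compounds named here, this change resembles the one from compound 2 to compound 3, so a lower number is expected, though the limit on compound 2 makes its size uncertain. Compound 4 is expected to give about 4000 nM, between 1800 nM and 10000 nM. That estimate means a step of an at least 2.5-fold lower number from compound 2 to compound 4 (0.39 log units; beyond the scatter) is expected.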

Compound 4, half-maximal inhibitory concentration: 2010 nM
Estimate against measurement, compound 4: 2.0-fold (0.30 log units) above; measured number inside the range.
By their numbers in this assay, from the lowest: compounds 4, 1 and 3 (each within the scatter of the next, the first and the last beyond it). At a limit, above all of these: compound 2.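

In this assay, phenyl in place of butyl on a saturated chain carbon, two bonds along the chain from an oxygen on an aromatic ring, gives an at least 4.9-fold lower number from compound 2 to compound 4 (0.69 log units; beyond the scatter). The earlier swap of a chain for a ring, leading to compound 3, had a floor that could not be told from the scatter, whereas this one clears it, so a phenyl at the end of the group on that oxygen clearly separates from the hexyl chain. For compound 2 the value is a limit, so this step is a floor and not a true size: the limit of > 10000 nM in this assay, at which 1 of the 4 values shown sits.

The compounds shown leave open whether an amine or a carboxylic acid at the end of the chain would give a similar step. They also leave open how a pyridine ring in place of the phenyl, or a longer chain between the oxygen and the phenyl, would read.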